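The source may report more compounds than this note shows. Statements on the series, on what has been measured and on what is new or still open speak of the compounds shown alone.

Measured in a functional assay on HL-60 cells (Homo sapiens) for antiproliferative activity, read by MTT assay, with a stated time of 48 h; a higher number here means a weaker inhibitor, a lower number a stronger inhibitor:
- Compound 1 `CN(C)CCCCn1c(N)c(-c2nc3ccccc3o2)c2nc(C#N)c(C#N)nc21`: 640 nM
- Compound 2 `CN(C)CCCCn1c(N)c(-c2nc3ccccc3s2)c2nc(C#N)c(C#N)nc21`: 830 nM
- Compound 3 `CCN(CC)CCn1c(N)c(-c2nc3ccccc3n2C)c2nc(C#N)c(C#N)nc21`: 8800 nM

Compound 3 holds the highest number of the three, and its gaps to compound 1 and compound 2 both lie beyond the scatter. The next compound to be tested, compound 4 `CN(C)CCCCn1c(N)c(-c2nc3ccccc3n2C)c2nc(C#N)c(C#N)nc21`, differs from compound 3 only in the chain: 2-(dimethylamino)ethyl in place of diethylamino on a saturated chain carbon, two bonds along the chain from an aromatic nitrogen. Read one bond further out, 2-(diethylamino)ethyl gives way to 4-(dimethylamino)butyl.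

Among the measured compounds shown here, no measured step changes this chain alone. For the measured compounds named here, the only step available, a 1.3-fold higher number from compound 1 to compound 2 (0.11 log units; within the scatter), lies within the scatter and sits at another place on the molecule, so it says nothing direct about the chain. Compound 1 and compound 2 already carry the 4-(dimethylamino)butyl chain, but they also differ from compound 3 in the group on the aromatic carbon, which compound 4 keeps from compound 3. The data do not show how much of the gap belongs to the chain. With compound 1 at 640 nM and compound 2 at 830 nM, a move to a lower number, beyond the scatter, is expected, though probably not the whole gap. The estimated change is a 4.9-fold lower number from compound 3 to compound 4 (0.69 log units; beyond the scatter). For compound 4 the expected value is 1800 nM, with an estimated range from 600 nM to 6000 nM.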

Compound 4, half-maximal inhibitory concentration: 740 nM
For compound 4 the middle estimate is 2.4-fold (0.39 log units) above the measured one; measured number inside the range.
By their numbers in this assay, from the lowest: compounds 1, 4 and 2 (each within the scatter of the next); then compound 3.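

In this assay, among the compounds shown here, the change of chain on its own, read as 2-(diethylamino)ethyl giving way to 4-(dimethylamino)butyl, brings a 12-fold lower number from compound 3 to compound 4 (1.08 log units; beyond the scatter) and is the first single change in this set to exceed the scatter. With the 4-(dimethylamino)butyl chain held fixed, 1-methyl-1H-benzimidazol-2-yl gives a 1.1-fold lower number from compound 2 to compound 4 (0.05 log units; within the scatter) against 1,3-benzothiazol-2-yl and a 1.2-fold higher number from compound 1 to compound 4 (0.06 log units; within the scatter) against 1,3-benzoxazol-2-yl, so on this chain the three groups on the aromatic carbon cannot be told apart in this assay. No measurement at hand accounts for the weight of the chain in this result.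

For the compounds shown here, the one step changes chain length and the groups on the amine nitrogen together, so these compounds do not show which of the two carries it; a 2-(dimethylamino)ethyl or a 4-(diethylamino)butyl chain on the same core would separate them. Also open, from the compounds shown here alone, are how a chain ending in a cyclic amine such as piperidine or morpholine, or a chain longer than butyl, would read, and whether the three groups on the aromatic carbon stay level on the shorter chain.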